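Swapping an Alkyne for a Methoxypyridine: Clearance Outlook

A few compounds are considered here, and "the series" means these few. Any claim that something is new, unique, unknown or untested is made for them only; others in the source may bear on it.

Compound 1 `COCC#Cc1cc(C(O)(C(F)(F)F)C(F)(F)F)cnc1N1CCN(S(=O)(=O)c2ccc(N)nc2)CC1` is tested in an ADME assay (liver) for metabolic stability, with Liver microsome (Homo sapiens) as the target, using microsomes and NADPH, with a stated time of 30 min, tested at 1 uM (on this read-out higher numbers stand for fast clearance and lower numbers for slow clearance), where compound 1 gives 15 mL.min-1.g-1, the lowest of the two numbers shown. Compound 2 `CC(C)(O)C#Cc1cc(C(O)(C(F)(F)F)C(F)(F)F)cnc1N1CCN(S(=O)(=O)c2ccc(N)nc2)CC1` reports only a limit of the assay, < 14 mL.min-1.g-1, not a number. Compound 3 `CC(C)(C)n1cc(-c2cc(C(O)(C(F)(F)F)C(F)(F)F)cnc2N2CCN(S(=O)(=O)c3ccc(N)nc3)CC2)cn1` gives 86 mL.min-1.g-1. The step of a 5.7-fold higher number from compound 1 to compound 3 (0.76 log units; beyond the scatter) and the step of an at least 6.1-fold higher number from compound 2 to compound 3 (0.78 log units; beyond the scatter) each put an aromatic ring in place of a triple-bonded chain. Compound 4 `COc1cncc(-c2cc(C(O)(C(F)(F)F)C(F)(F)F)cnc2N2CCN(S(=O)(=O)c3ccc(N)nc3)CC2)c1` differs from compound 1 in a related way: 5-methoxypyridin-3-yl in place of 3-methoxyprop-1-yn-1-yl on an aromatic carbon. Because the step of a 5.7-fold higher number from compound 1 to compound 3 (0.76 log units; beyond the scatter) went up when an aromatic ring replaced the alkyne, a modest rise is expected here as well, a 2.7-fold higher number from compound 1 to compound 4 (0.43 log units; beyond the scatter). For compound 4 the estimate in this assay is 40 mL.min-1.g-1, expected to fall between 18 mL.min-1.g-1 and 90 mL.min-1.g-1.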

Compound 4, intrinsic clearance in microsomes: 44 mL.min-1.g-1
Beside the measured number, compound 4's estimate is 1.1-fold (0.04 log units) below it; measured number inside the range.
By their numbers in this assay, from the lowest: compound 1; then compounds 4 and 3 (each within the scatter of the next). At a limit, below all of these: compound 2.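

In this assay, this position now shows a second kind of aromatic ring giving a higher number than the alkynes, with a 2.9-fold higher number from compound 1 to compound 4 (0.47 log units; beyond the scatter) and an at least 3.1-fold higher number from compound 2 to compound 4 (0.49 log units; beyond the scatter). The 5-methoxypyridin-3-yl and 1-(tert-butyl)-1H-pyrazol-4-yl groups are not separated, with a 2.0-fold lower number from compound 3 to compound 4 (0.29 log units; within the scatter). Compound 2 stands at a limit of the assay, so its step gives only a bound: the limit of < 14 mL.min-1.g-1 in this assay, at which 1 of the 4 values shown sits.

Still open, going by these compounds, is whether a saturated ring such as morpholine, or an unsubstituted pyridin-3-yl, at this position would bring the number back towards that of compound 1.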